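From Methyl to Methoxy on an Aromatic Carbon

This account rests on a few compounds, and the source may have more. Where it says the series, first, only, none or still open, it means among the compounds named here.

Of the compounds shown here, two have been measured so far in a functional assay (HSMC cells, Homo sapiens) for antiproliferative activity, with a stated time of 72 h; a higher number here means a weaker inhibitor, a lower number a stronger inhibitor. There, compound 1 `COC(=O)[C@H](CCSC)NC(=O)c1ccc(OC[C@@H]2COc3ccccc3O2)cc1-c1ccccc1C` gives 193000 nM. Alongside it, compound 2 `COC(=O)[C@H](CCSC)NC(=O)c1ccc(OC[C@H]2COc3ccccc3O2)cc1-c1ccccc1OC` gives 230000 nM. For the measured compounds named here, these two numbers lie within the usual scatter of each other, so compound 1 stands level with the only other measured compound, and neither can be ranked above the other.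

The step followed here leads to compound 3 `COC(=O)[C@H](CCSC)NC(=O)c1ccc(OC[C@@H]2COc3ccccc3O2)cc1-c1ccccc1OC`. It differs from compound 1 by methoxy in place of methyl on an aromatic carbon, ortho to a large group: methoxy in place of methyl on an aromatic carbon. The same difference, cut one bond further out, reads 2-methylphenyl to 2-methoxyphenyl. Going by the values given here, no measured pair shows this change on its own, so there is no direct step to go by. Compound 2 also carries the 2-methoxyphenyl group and gives 230000 nM, a value within the scatter of compound 1 at 193000 nM. No shift beyond the scatter, in either direction, is therefore expected in this assay, and the estimated change is a 1.0-fold higher number from compound 1 to compound 3 (0.02 log units; within the scatter). For compound 3 the expected value is 200000 nM, with an estimated range from 100000 nM to 400000 nM.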

Compound 3, half-maximal inhibitory concentration: 204000 nM
The estimate for compound 3 lay 1.0-fold (0.01 log units) below the measured number, and the stated range covers the measured number.
By their numbers in this assay, from the lowest: compounds 1, 3 and 2 (each within the scatter of the next).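

With the configuration held the same, methoxy in place of methyl on an aromatic carbon, ortho to a large group, gives a 1.1-fold higher number from compound 1 to compound 3 (0.02 log units; within the scatter) in this assay, so this change can now be read on its own, and it leaves the two compounds level. For the compounds shown here, the stereocentre at the saturated ring carbon can also be read for the first time: the drawn S and R forms show a 1.1-fold lower number from compound 2 to compound 3 (0.05 log units; within the scatter), and they stand level as well. This second reading concerns the stereocentre alone, and it rests on one point: the fact that compounds 2 and 3 differ only in the configuration as drawn.

Neither the 2-methoxyphenyl group nor the stereocentre has therefore shown a shift beyond the scatter, but these readings cover only methyl and methoxy at this place and a single step at the stereocentre, so whether a hydroxyl group, an amine or a chlorine atom there would behave the same stays open. Also open, from the compounds shown here alone, is whether a free carboxylic acid in place of the methyl ester, elsewhere on the shared core, would move the number beyond the scatter in this assay.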